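Swapping Propoxy for Diethylamino on the Shared Core

The compounds below may be only part of what the source reports. "The series", "measured", "known", "first", "only" and "open" are said of these compounds alone.

Compound 1, `CCOc1ccc2cc(C(=O)NCCO)c(=O)oc2c1`, gives > 100000 nM in a functional assay on HCT-116 cells (Homo sapiens) for cytotoxicity, read by MTT assay, with a stated time of 72 h; on this read-out higher numbers stand for weaker inhibition and lower numbers for stronger inhibition; this is a limit of the assay, not a number.
Compound 2, `CCCOc1ccc2cc(C(=O)NCCO)c(=O)oc2c1`, gives > 100000 nM in this assay; this too is a limit.
Compound 3, `O=C(NCCO)c1cc2ccc(OCc3ccc([N+](=O)[O-])cc3)cc2oc1=O`, gives 33400 nM in this assay.

Compound 2 sits at the limit of > 100000 nM in this assay, at which 2 of the 3 values shown sit, the weakest result the assay can record. Compound 4, `CCN(CC)c1ccc2cc(C(=O)NCCO)c(=O)oc2c1`, differs from compound 2 by diethylamino in place of propoxy on an aromatic carbon. Among the measured compounds shown here, no measured step trades an oxygen-linked group for a nitrogen-linked one. The step that the two limits leave unreadable from compound 1 to compound 2 is unreadable, and an at least 2.9-fold lower number from compound 2 to compound 3 (0.47 log units; beyond the scatter) came from adding 4-nitrophenyl, a change unlike this one. For the measured compounds named here, with no guiding step, a step of no readable size is expected, a number no higher from compound 2 to compound 4 (the limit leaves the size open). Compound 4 is therefore expected to give 100000 nM, somewhere between 30000 nM and 300000 nM.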

Compound 4, half-maximal inhibitory concentration: > 100000 nM
Compound 4: a limit, no number (the forecaster's own chance of this, stated with the estimate: 60%); the middle value lies on the limit itself.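

Compound 4 gives > 100000 nM, a limit and not a number, and compound 1 and compound 2 also sit at limits, so neither step to compound 4 can be read. Going by these compounds, how ethoxy, propoxy and diethylamino truly compare in this assay remains open.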